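The compounds below may be only part of what the source reports. "The series", "measured", "known", "first", "only" and "open" are said of these compounds alone.

Compound 2, `CCCCCCCCCCCCCCCCCCNC(=O)[C@@H]1CSC(c2ccc(O)cc2)N1`, was examined in a functional assay on PC-3 cells (Homo sapiens) for antiproliferative activity, read by sulforhodamine B assay (a lower number here means a stronger inhibitor, a higher number a weaker inhibitor), where compound 2 gives 5300 nM. Among the two numbers so far, compound 2 stands highest; its nearest neighbour is compound 1, `CCCCCCCCCCCCCCCCCCNC(=O)[C@@H]1CSC(c2cc(OC)c(OC)c(OC)c2)N1`, which in this assay gives 4000 nM, and the step of a 1.3-fold higher number from compound 1 to compound 2 (0.12 log units; within the scatter) lies within the usual scatter. Compound 3, `CCCCCCCCCCCCCCCCCCNC(=O)[C@@H]1CSC(c2ccc(OCC)cc2)N1`, departs from compound 2 by ethyl in place of hydrogen on an oxygen on an aromatic ring, that is, hydroxy to ethoxy on the aryl group attached to the saturated ring carbon. Within the data shown here, no measured step bears directly on this change: the only step known exchanges the whole aryl group, from compound 1 to compound 2, and it stayed within the scatter. On that thin evidence, no step beyond the scatter is expected from compound 2 to compound 3. The expectation for compound 3 is therefore 4500 nM, within a range of 1800 nM to 12000 nM, which amounts to an expected step of a 1.2-fold lower number from compound 2 to compound 3 (0.07 log units; within the scatter).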

Compound 3, half-maximal inhibitory concentration: > 20000 nM
Compound 3 gave a limit, no number (the forecaster's own chance of this, stated with the estimate: 10%); at least 4.4-fold (0.64 log units) between middle value and limit.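

Compound 3 is recorded in this assay only as a limit, not as a number: the limit of > 20000 nM in this assay, at which 1 of the 3 values shown sits. Even so, the oxygen on the aromatic ring proves responsive to substitution: ethyl in place of hydrogen there gives an at least 3.7-fold higher number from compound 2 to compound 3 (0.57 log units; beyond the scatter), the first step in this series beyond the scatter, whereas the exchange of the whole aryl group in a 1.3-fold higher number from compound 1 to compound 2 (0.12 log units; within the scatter) stayed within it. The 4-ethoxyphenyl group also compares poorly with the 3,4,5-trimethoxyphenyl group, with an at least 5.0-fold higher number from compound 1 to compound 3 (0.69 log units; beyond the scatter), so ether oxygens on the aryl group do not alone set the level, as compound 1 carries three methoxy groups.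

How far compound 3 lies past its limit cannot be read. On these data alone, it remains open whether a single methoxy group, a longer propoxy chain or an amine at this place would track compound 2 or compound 3.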